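The source may report more compounds than this note shows. Statements on the series, on what has been measured and on what is new or still open speak of the compounds shown alone.

- Compound 1 `C=CC(=O)N1C(=O)CC(c2ccc(C(F)(F)F)cc2)Sc2ccccc21`: 76300 nM
- Compound 2 `C=CC(=O)N1C(=O)CC(c2ccc(Cl)cc2)Sc2ccccc21`: 82400 nM

Both values come from a functional assay on MOLT-4 cells (Homo sapiens) for cytotoxicity, read by CCK-8 assay, with a stated time of 24 h; a lower number here means a stronger inhibitor, a higher number a weaker inhibitor. Compound 2, at 82400 nM, stands level with compound 1 within the scatter, so no order can be drawn between the two. Compound 3 `C=CC(=O)N1C(=O)CC(c2ccc(-c3ccccc3)cc2)Sc2ccccc21` keeps the shared core and carries phenyl in place of chloro on an aromatic carbon, para to a large group: phenyl in place of chloro on an aromatic carbon. Within the data shown here, the only measured step that bears on this change is a 1.1-fold higher number from compound 1 to compound 2 (0.03 log units; within the scatter), with chloro in place of trifluoromethyl. Among the measured compounds shown here, that step is small, but no measured step brings a ring onto this carbon, so it is only a weak guide. No step beyond the scatter is therefore expected in this assay, and any lean towards a lower number is tentative. The expected step is a 1.3-fold lower number from compound 2 to compound 3 (0.10 log units; within the scatter). Compound 3 is estimated at 65000 nM, with an expected range of 28000 nM to 130000 nM.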

Compound 3, half-maximal inhibitory concentration: 97500 nM
Compound 3: the middle estimate sits 1.5-fold (0.18 log units) below what was measured; the measured number falls inside the stated range.
By their numbers in this assay, from the lowest: compounds 1, 2 and 3 (each within the scatter of the next).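

In this assay, phenyl in place of chloro gives a 1.2-fold higher number from compound 2 to compound 3 (0.07 log units; within the scatter), and phenyl in place of trifluoromethyl gives a 1.3-fold higher number from compound 1 to compound 3 (0.11 log units; within the scatter); both steps lie within the scatter. Among these compounds, compound 3 is the only one of the three that carries a ring on this aromatic carbon, so this is the first reading of what a ring does here. Going from a single heavy atom in chloro to six in phenyl produces no step that can be told from the scatter, so among these three compounds, neither the size of the group nor the added ring separates the numbers.

From the compounds shown here alone, whether an amine or a carboxylic acid on this carbon would move the number beyond the scatter stays open. No measurement at hand offers an explanation for these results.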